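Dropping the Acetamido Group: Expected Solubility of Compound 3

This account rests on a few compounds, and the source may have more. Where it says the series, first, only, none or still open, it means among the compounds named here.

Of the compounds shown here, two have so far been measured in a physicochemical assay for solubility, in simulated intestinal fluid; on this read-out higher numbers stand for higher solubility and lower numbers for lower solubility. Compound 1 `Cc1nc(N)nc(-c2c(Nc3ccn(C)n3)nc3ccc(-c4cncnc4)cn23)n1` gives 1 ug/mL. Compound 2 `CC(=O)Nc1cc(-c2c(Nc3cc[nH]n3)nc3cccnn23)nc(C)n1` gives 200 ug/mL, the higher of the two numbers and a step from compound 1 that lies well beyond the usual scatter. Compound 3 `Cc1nccc(-c2c(Nc3cc[nH]n3)nc3cccnn23)n1` has not yet been measured; it differs from compound 2 by hydrogen in place of acetamido on an aromatic carbon, in words hydrogen in place of acetamido on an aromatic carbon. Going by the values given here, no measured pair shows this exact change, so its effect cannot be read off from the data at hand. Because compound 2 gives 200 ug/mL, the starting point is already high, and the step from compound 2 to compound 3 is expected to be a modest decrease, estimated at a 2.0-fold lower number from compound 2 to compound 3 (0.30 log units; within the scatter), close to the edge of the scatter. Compound 3 is therefore expected to give about 100 ug/mL, within a range from 20 ug/mL to 400 ug/mL.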

Compound 3, solubility: 14 ug/mL
For compound 3 the middle estimate is 7.1-fold (0.85 log units) above the measured one; the whole stated range lies above it.
By their numbers in this assay, from the lowest: compound 1; then compound 3; then compound 2.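

Going by these compounds alone, this is the first pair here that differs in only one place, so it gives the first direct reading of this position, an aromatic carbon of a six-membered aromatic ring with 2 nitrogen. In this assay, hydrogen in place of acetamido gives a 14-fold lower number from compound 2 to compound 3 (1.15 log units; beyond the scatter), which shows that the read-out is not indifferent to what sits on this carbon. Nothing available explains the size or direction of this step.

On these data alone, it remains open whether a methoxy group or a carboxylic acid on this carbon would give a number nearer that of compound 2 or that of compound 3. As far as these compounds go, it is also open whether the same change would give a similar step on the core of compound 1, which differs from compound 2 in more than one place.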